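The source may report more compounds than this note shows. Statements on the series, on what has been measured and on what is new or still open speak of the compounds shown alone.

Of the compounds shown here, three have been measured here in a functional assay on the whole organism for inhibition, with Rattus norvegicus as the target; on this read-out higher numbers stand for weaker inhibition and lower numbers for stronger inhibition. Compound 1, with the structure `COc1cc2c(cc1O)C(=O)CC(C(=O)O)O2`, gives 105000 nM. Compound 2, with the structure `CCCCNC(=O)C1CCc2cc(O)c(OC)cc2O1`, gives 24800 nM in this assay, the lowest of the three numbers. Compound 3, with the structure `CCCCNC(=O)C1CC(=O)c2cc(O)c(OC)cc2O1`, gives 66400 nM in this assay. Compound 2 and compound 3 differ in more than one place, so the difference between their two cores is not broken down here; their values simply show that compound 2 sits lower, beyond the scatter.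

Compound 3 and compound 1 differ in one place only: hydroxy in place of butylamino on a carbonyl carbon. This change produced a 1.6-fold higher number from compound 3 to compound 1 (0.20 log units; within the scatter) in this assay, so it left the number essentially where it was.

Compound 4, with the structure `COc1cc2c(cc1O)CCC(C(=O)O)O2`, has not yet been measured. It relates to compound 2 exactly as compound 1 relates to compound 3: hydroxy in place of butylamino on a carbonyl carbon. Since the two surroundings are the same, this is the same change. Because the same change gave only a 1.6-fold higher number from compound 3 to compound 1 (0.20 log units; within the scatter), the step from compound 2 to compound 4 is expected to be similarly small, an estimated 1.6-fold higher number from compound 2 to compound 4 (0.21 log units; within the scatter) in this assay. That expectation rests on a single earlier pair, so it carries real uncertainty. On this basis compound 4 is estimated to give about 40000 nM in this assay, most likely between 15000 nM and 110000 nM.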

Compound 4, half-maximal inhibitory concentration: 16800 nM
Compound 4: middle estimate off by 2.4-fold (0.38 log units), on the high side; low and high end bracket the measured number.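

In this assay, putting hydroxy in place of butylamino on the carbonyl carbon gives a 1.5-fold lower number from compound 2 to compound 4 (0.17 log units; within the scatter), so on this core too the step stays within the usual scatter. Within the data shown here, the two steps point in opposite directions on paper, but the gap between them is no larger than two such steps can show from scatter alone, so on both cores this change makes no clear difference to the number: the same change on two cores in this assay, a 1.6-fold higher number (0.20 log units; within the scatter) from compound 3 to compound 1 and a 1.5-fold lower number (0.17 log units; within the scatter) from compound 2 to compound 4, 2.3-fold (0.37 log units) apart, within the scatter of two such steps This does not show that hydroxy and butylamino can always replace each other, as it rests on only two pairs of compounds, and it does not explain why the number stays put.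

The compounds shown leave open what other groups on this carbonyl carbon would do, as only butylamino and hydroxy stand there: a shorter chain such as methylamino, a longer chain such as octylamino, a ring amine such as piperidine or a methyl ester could each give a different picture. Going by these compounds, it also remains open whether this same change would stay as small on any core other than these two.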